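Solubility notes: aryl swap from compound 1 to compound 4

The source may hold more compounds than are shown below. What is called first, only, known or untested is meant among the compounds shown, and "the series" means these compounds.

Measured so far in a physicochemical assay for solubility, in phosphate buffer, measured as kinetic solubility, with a stated time of 1 h, at pH 7.4; on this read-out higher numbers stand for higher solubility and lower numbers for lower solubility:
compound 1 `COc1ccc2nc(C)cc(OCC(=O)Nc3cc(C)cc(C)c3)c2c1` gives 26000 nM
compound 2 `CCC(Oc1cc(C)nc2ccc(OC)cc12)C(=O)Nc1cc(C)cc(C)c1` gives 123000 nM
compound 3 `COc1ccc2nc(C)cc(OCC(=O)Nc3cc(C)c(OC)c(C)c3)c2c1` gives 17000 nM

Compound 1 stands second highest of the three numbers; compound 3 is nearest, and compound 2 is furthest, above it. Two single-point steps from compound 1 are known: a 4.7-fold higher number from compound 1 to compound 2 (0.67 log units; beyond the scatter), and a 1.5-fold lower number from compound 1 to compound 3 (0.18 log units; within the scatter).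

Compound 4 `COc1ccc2nc(C)cc(OCC(=O)Nc3ccc(Br)c(C)c3)c2c1` is not yet measured. It differs from compound 1 only on the amide-type nitrogen: 4-bromo-3-methylphenyl in place of 3,5-dimethylphenyl on an amide-type nitrogen. Neither measured step touches this part of the molecule: the step to compound 2 alters the chain carbon bound to the carbonyl carbon, and the step to compound 3 adds a methoxy on an aromatic carbon, staying within the scatter. Going by the values given here, no exchange of one aryl group for another has been measured, so there is no direct precedent. A bromine standing in for one methyl at equal heavy-atom count is expected to leave the number near that of compound 1, with the step of a 1.3-fold lower number from compound 1 to compound 4 (0.11 log units; within the scatter) estimated to fall within or just beyond the scatter. For compound 4 the estimate in this assay is 20000 nM, with a range of 8000 nM to 50000 nM.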

Compound 4, solubility: < 1000 nM
Compound 4 gave a limit, no number (the forecaster's own chance of this, stated with the estimate: 5%); middle value at least 20-fold (1.30 log units) from the limit.
By their numbers in this assay, from the lowest: compounds 3 and 1 (each within the scatter of the next); then compound 2. At a limit, below all of these: compound 4.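

The aryl group on the amide-type nitrogen is not a neutral place in this series. In this assay, adding methoxy to that aryl group stays within the scatter, with a 1.5-fold lower number from compound 1 to compound 3 (0.18 log units; within the scatter), whereas 4-bromo-3-methylphenyl in place of 3,5-dimethylphenyl gives an at least 26-fold lower number from compound 1 to compound 4 (1.41 log units; beyond the scatter), even though both groups count the same heavy atoms and no hydrogen-bond donors or acceptors. Compound 4 stands at a limit and not at a number: the limit of < 1000 nM in this assay, at which 1 of the 4 values shown sits.

The compounds shown do not separate the bromine itself from the changed arrangement of groups on the ring, which a chlorine or a methyl in place of the bromine would address. Also open, on these data alone, is whether the ethyl on the chain of compound 2, or an amine on the aryl group, would restore a measurable number alongside the 4-bromo-3-methylphenyl group.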